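The source may hold more compounds than are shown below. What is called first, only, known or untested is meant among the compounds shown, and "the series" means these compounds.

Of the compounds shown here, two have so far been tested in a functional assay on DU-145 cells (Homo sapiens) for inhibition, read by trypan blue exclusion, with a stated time of 96 h; a lower number here means a stronger inhibitor of growth, a higher number a weaker inhibitor of growth. Compound 1 (`O=C(O)c1ccc(C(=O)/C(=C\c2ccc([N+](=O)[O-])c(O)c2)SCc2ccc(Br)cc2)cc1`) gives 10000 nM, and compound 2 (`O=C(O)c1ccc(C(=O)/C(=C\c2ccc(Br)c([N+](=O)[O-])c2)SCc2ccc(Cl)cc2Cl)cc1`) gives 1000 nM, the lower of the two numbers, with a gap beyond the usual scatter. These two compounds differ in more than one place, so the gap cannot be assigned to any single change.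

Compound 3 (`O=C(O)c1ccc(C(=O)/C(=C\c2ccc(Br)c([N+](=O)[O-])c2)SCc2ccc(Br)cc2)cc1`) differs from compound 2 in one place only: 4-bromophenyl in place of 2,4-dichlorophenyl on a saturated chain carbon bound to a sulfur. Here, 4-bromophenyl stands in place of 2,4-dichlorophenyl on a saturated chain carbon bound to a sulfur. The same 4-bromophenyl is present in compound 1, which gives 10000 nM, but that compound also differs elsewhere, so it offers only a weak hint toward a higher number. Going by the values given here, no measured pair shows this change alone, so a small move in this assay toward weaker growth inhibition is expected, probably not beyond the scatter. The estimated change is a 1.5-fold higher number from compound 2 to compound 3 (0.18 log units; within the scatter). For compound 3 the estimated value is 1500 nM, with an expected range from 500 nM to 5000 nM.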

Compound 3, concentration for 50% growth inhibition: 1000 nM
The estimate for compound 3 lay 1.5-fold (0.18 log units) above the measured number; low and high end bracket the measured number.
By their numbers in this assay, from the lowest: compounds 2 and 3 (each within the scatter of the next); then compound 1.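

In this assay the step of no change at the digits printed from compound 2 to compound 3 (within the scatter) shows that, on the saturated chain carbon bound to a sulfur, 2,4-dichlorophenyl and 4-bromophenyl cannot be told apart in this pair, even though one carries two chlorine atoms and the other a single bromine. Going by these compounds alone, compound 3 also gives compound 1 a partner that differs in one place only, which the earlier pair lacked: with 4-bromophenyl on the sulfur side of both, 4-bromo-3-nitrophenyl in place of 3-hydroxy-4-nitrophenyl on the double-bonded chain carbon gives a 10-fold lower number from compound 1 to compound 3 (1.00 log units; beyond the scatter) and is the only step here beyond the scatter. No measurement shown here offers a reason for either result.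

The step from compound 1 to compound 3 replaces one ring group with another that differs in two substituents, so it cannot say whether the bromine, the loss of the hydroxyl or the altered nitro placement matters. Also open, on these data alone, is whether an unsubstituted phenyl or a pyridine on the sulfur side would leave the number as unchanged as 4-bromophenyl does.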